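A few compounds are considered here, and "the series" means these few. Any claim that something is new, unique, unknown or untested is made for them only; others in the source may bear on it.

Compound 1 `O=C(Nc1cccc(-n2cc(-c3ccncc3)c(-c3ccc(Cl)c(O)c3)n2)c1)Nc1ccc(Cl)c(Cl)c1`: > 32500 nM
Compound 2 `O=C(Nc1cccc(-n2cc(-c3ccncc3)c(-c3ccc(Cl)c(O)c3)n2)c1)Nc1cc(C(F)(F)F)cc(C(F)(F)F)c1`: 3810 nM
Compound 3 `COc1cc(-c2nn(-c3cccc(NC(=O)Nc4cccc(C(F)(F)F)c4)c3)cc2-c2ccncc2)ccc1Cl`: > 50000 nM

In a functional assay on SK-OV-3 cells (Homo sapiens) for inhibition, read by sulforhodamine B assay, with a stated time of 48 h (on this read-out lower numbers stand for stronger inhibition of growth and higher numbers for weaker inhibition of growth), compound 2 gives 3810 nM. For compound 1 the result is a limit of the assay, > 32500 nM. For compound 3 the result is also a limit, > 50000 nM. Compound 3 thus stands only at a limit (the limit of > 50000 nM in this assay, at which 1 of the 3 values shown sits), and one other value shown is likewise a limit (the limit of > 32500 nM in this assay, at which 1 of the 3 values shown sits). Compound 4 `O=C(Nc1cccc(-n2cc(-c3ccncc3)c(-c3ccc(Cl)c(O)c3)n2)c1)Nc1cccc(C(F)(F)F)c1` differs from compound 3 by hydrogen in place of methyl on an oxygen on an aromatic ring. Among the compounds with values here, no measured pair isolates this change, so its size is open. Because compound 2, which carries the hydroxy, gives 3810 nM rather than a limit, compound 4 is expected to move toward measurable inhibition, a step of an at least 3.3-fold lower number from compound 3 to compound 4 (0.52 log units; beyond the scatter) expected beyond the scatter but uncertain. Compound 4 is estimated at 15000 nM, between 4000 nM and 50000 nM.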

Compound 4, concentration for total growth inhibition: > 32500 nM
Compound 4: only a limit was reported; the forecaster's own chance of this, stated with the estimate: 40%; middle value at least 2.1-fold (0.33 log units) away from the limit.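

Compound 4 gives only a limit of the assay: the limit of > 32500 nM in this assay, at which 2 of the 4 values shown sit. The hydroxy on the 4-chloro-3-hydroxyphenyl group therefore does not by itself bring measurable inhibition, since hydrogen in place of trifluoromethyl on an aromatic carbon gives an at least 8.5-fold higher number from compound 2 to compound 4 (0.93 log units; beyond the scatter). The steps to compound 4 from compound 3 and from compound 1 cannot be read.

From the compounds shown here alone, the effect of methoxy to hydroxy thus stays open in this assay. Going by these compounds, it is also open whether an amine or a carboxylic acid in place of that trifluoromethyl would keep the inhibition seen with compound 2.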